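Notes on an aryl-to-triazolylmethyl swap in the series

The source may report more compounds than this note shows. Statements on the series, on what has been measured and on what is new or still open speak of the compounds shown alone.

Three compounds have numbers in an assay on isolated protein for inhibition of sodium-dependent phosphate transport protein 2B (Homo sapiens); a lower number here means a stronger inhibitor, a higher number a weaker inhibitor. Compound 1 `CCC(CC)N(CCN(C)C(=O)CCC(=O)O)Cc1cccc(C(=O)Nc2sc3c(c2C(=O)c2cnn(-c4ccc(Cl)cc4)c2)CCOC3)c1` gives 437 nM and compound 2 `CCC(CC)N(CCN(C)C(=O)CCC(=O)O)Cc1cccc(C(=O)Nc2sc3c(c2C(=O)c2cnn(-c4ccc(Cl)cc4)c2)CCSC3)c1` gives 713 nM. Compound 3 `CCC(CC)N(CCN(C)C(=O)CCC(=O)O)Cc1cccc(C(=O)Nc2sc3c(c2C(=O)c2cnn(-c4cccc(C(F)(F)F)c4)c2)CCC(C)(C)C3)c1` gives 46 nM, the lowest of the three; its gaps to compound 1 and to compound 2 both lie beyond the usual scatter. Compound 4 `CCC(CC)N(CCN(C)C(=O)CCC(=O)O)Cc1cccc(C(=O)Nc2sc3c(c2C(=O)c2cnn(Cc4nnc[nH]4)c2)CCC(C)(C)C3)c1` differs from compound 3 in one place: (4H-1,2,4-triazol-3-yl)methyl in place of 3-(trifluoromethyl)phenyl on an aromatic nitrogen. Among the measured compounds shown here, no pair of measured compounds differs in only this way, so the size of this step cannot be read off from the data, and compounds 1 and 2 differ from compound 3 in more than one place, so they give no direct guide. For compound 4 a step beyond the scatter toward a higher number, a 5.4-fold higher number from compound 3 to compound 4 (0.74 log units; beyond the scatter), is expected in this assay. Compound 4 is estimated at 250 nM, with a range from 60 nM to 1000 nM.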

Compound 4, half-maximal inhibitory concentration: > 1000 nM
Compound 4 ended at the assay's limit; the forecaster's own chance of this, stated with the estimate: 5%; at least 4.0-fold (0.60 log units) between middle value and limit.
By their numbers in this assay, from the lowest: compound 3; then compounds 1 and 2 (each within the scatter of the next). At a limit, above all of these: compound 4.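

At this aromatic nitrogen, (4H-1,2,4-triazol-3-yl)methyl in place of 3-(trifluoromethyl)phenyl gives an at least 21-fold higher number from compound 3 to compound 4 (1.33 log units; beyond the scatter) in this assay. This is the only single-place step shown, and it establishes that the group on this nitrogen matters for the read-out, which compounds 1 and 2 could not show. The value for compound 4 is a limit, not a number: the limit of > 1000 nM in this assay, at which 1 of the 4 values shown sits.

On these data alone, it remains open which part of the change carries the step, since a benzyl group on the same nitrogen would separate the ring type from the methyl linker. Also open, as far as these compounds go, is how 4-chlorophenyl would compare with 3-(trifluoromethyl)phenyl on the core of compound 3.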